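Methyl-to-hydrogen step across two cores

The source may hold more compounds than are shown below. What is called first, only, known or untested is meant among the compounds shown, and "the series" means these compounds.

Compound 1 `Cc1ccc2[nH]c(C)nc2c1` and compound 2 `Cc1nc2c(C)c(C)ccc2[nH]1` share one core; compound 3 `Cc1ccc(OCc2nc3ccccc3[nH]2)cc1C` is built on a different and larger core. In an ADME assay on microsomes from liver for inhibition of cytochrome P450 2B1 (Rattus norvegicus) (on this read-out lower numbers stand for stronger inhibition and higher numbers for weaker inhibition), compound 1 gives 479000 nM, compound 2 gives 251000 nM, and compound 3 gives 25700 nM, the lowest number of the three and beyond the scatter from both others. The difference between the core of compound 2 and that of compound 3 is not broken down here. Between compound 2 and compound 1 the change is hydrogen in place of methyl on an aromatic carbon and the step is a 1.9-fold higher number from compound 2 to compound 1 (0.28 log units; within the scatter). Compound 4 `Cc1cccc(OCc2nc3ccccc3[nH]2)c1` is still to be measured in this assay; it relates to compound 3 by hydrogen in place of methyl on an aromatic carbon. This is the same kind of change as that from compound 2 to compound 1, not the same: there the place was part of a fused or bridged system of two rings, ortho to a fused ring and meta to a fused ring, whereas in compound 4 it is para to a large group. Given that the earlier step of a 1.9-fold higher number from compound 2 to compound 1 (0.28 log units; within the scatter) lies within the scatter, the expected step is a 1.4-fold higher number from compound 3 to compound 4 (0.13 log units; within the scatter), resting on that single precedent only. Compound 4 is therefore estimated at 35000 nM, between 15000 nM and 85000 nM.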

Compound 4, half-maximal inhibitory concentration in the cytochrome P450 2B1 assay: 28800 nM
Compound 4: middle estimate off by 1.2-fold (0.08 log units), on the high side; the measured number falls inside the stated range.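

In the cytochrome P450 2B1 assay, hydrogen in place of methyl on an aromatic carbon gives a 1.1-fold higher number from compound 3 to compound 4 (0.05 log units; within the scatter). In a physicochemical assay for lipophilicity (a lower number here means a more polar compound, a higher number a more lipophilic compound), compound 3 gives 3.4 and compound 4 gives 3.14, and the same change gives a number 0.26 log units lower from compound 3 to compound 4 (within the scatter). Set beside the earlier step on the other core, the change gives a step within the scatter on both cores, at different places on the ring: the same change on two cores in the cytochrome P450 2B1 assay, a 1.9-fold higher number (0.28 log units; within the scatter) from compound 2 to compound 1 and a 1.1-fold higher number (0.05 log units; within the scatter) from compound 3 to compound 4, 1.7-fold (0.23 log units) apart, within the scatter of two such steps This shows only that, for these two pairs, losing this methyl group leaves the inhibition read-out unchanged within the scatter; it does not show that a step of real size would carry from one core to the other, and two pairs establish no rule for the series.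

The compounds shown leave open whether a different group at these places, such as a methoxy group, a chlorine atom, an amine or a carboxylic acid, would shift the number in the cytochrome P450 2B1 assay. Within the data shown here, they also leave open which part of the difference between the core of compound 2 and that of compound 3 goes with the lower number of compound 3, as no pair here breaks that difference down.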